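This account rests on a few compounds, and the source may have more. Where it says the series, first, only, none or still open, it means among the compounds named here.

Measured compounds:
compound 1, `COc1nc(-c2ccc(Br)cc2)ccc1[C@@H](c1ccccc1)[C@@](O)(CCN(C)C)c1cccc2ccccc12`: > 64 ug/mL
compound 2, `COc1ncc(-c2ccccc2)cc1[C@@H](c1ccccc1)[C@@](O)(CCN(C)C)c1cccc(F)c1F`: 28.1 ug/mL

In a toxicity assay on HeLa cells (Homo sapiens) for cytotoxicity (a lower number here means that less compound is tolerated, a higher number that more compound is tolerated), compound 1 gives > 64 ug/mL, which is a limit of the assay rather than a number (the limit of > 64 ug/mL in this assay, at which 1 of the 2 values shown sits). In this assay compound 2 gives 28.1 ug/mL. Within the data shown here, the two compounds differ in more than one place, so no single step connects them.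

Compound 3, `COc1nc(-c2ccc(OC(F)(F)F)cc2)ccc1[C@@H](c1ccccc1)[C@@](O)(CCN(C)C)c1cccc2ccccc12`, differs from compound 1 by trifluoromethoxy in place of bromo on an aromatic carbon. Among the measured compounds shown here, no measured step of this kind exists here, and the account expects none beyond the scatter: the step is estimated as a number no higher from compound 1 to compound 3 (the limit leaves the size open). Compound 3 is therefore expected to give about 64 ug/mL in this assay, with a range from 30 ug/mL to 130 ug/mL, and most likely again only a limit.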

Compound 3, half-maximal cytotoxic concentration: > 64 ug/mL
Compound 3: no number, only a limit; the forecaster's own chance of this, stated with the estimate: 70%; the middle value sits exactly at the limit.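

Compound 1 and compound 3 both give only a limit in this assay, so no step can be read between them: the limit of > 64 ug/mL in this assay, at which 2 of the 3 values shown sit. The compounds shown leave open whether trifluoromethoxy in place of bromo changes this read-out at all.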